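Side chain on sulfur: compound 2 to compound 3

The source may hold more compounds than are shown below. What is called first, only, known or untested is meant among the compounds shown, and "the series" means these compounds.

In a functional assay on HT cells (Homo sapiens) for antiproliferative activity, read by fluorescence, with a stated time of 72 h (a lower number here means a stronger inhibitor of growth, a higher number a weaker inhibitor of growth), compound 1 `CC(C)c1n[nH]c2c(NCc3ccc(-c4ccccn4)cc3)nc(SCC3CNC(=O)O3)nc12` gives 80 nM and compound 2 `CC(C)c1n[nH]c2c(NCc3ccc(-c4ccccn4)cc3)nc(SCCCO)nc12` gives 109 nM, two values within the scatter of each other. Compound 3 `CC(C)c1n[nH]c2c(NCc3ccc(-c4ccccn4)cc3)nc(SC3CCCC3O)nc12` carries 2-hydroxycyclopentyl in place of 3-hydroxypropyl on a sulfur. Within the data shown here, the one measured step bearing on this, a 1.4-fold higher number from compound 1 to compound 2 (0.13 log units; within the scatter), also alters the chain on the sulfur and stays within the scatter, so no shift beyond the scatter is expected in this assay, though a single step is thin support. The expected step is a 1.1-fold higher number from compound 2 to compound 3 (0.04 log units; within the scatter). For compound 3 the estimated value is 120 nM, with an expected range of 50 nM to 290 nM.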

Compound 3, concentration for 50% growth inhibition: 567 nM
Compound 3: the middle estimate sits 4.7-fold (0.67 log units) below what was measured; the whole stated range lies below it.
By their numbers in this assay, from the lowest: compounds 1 and 2 (each within the scatter of the next); then compound 3.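

Among these compounds, the side chain on the sulfur is not indifferent in this assay: 2-hydroxycyclopentyl in place of 3-hydroxypropyl gives a 5.2-fold higher number from compound 2 to compound 3 (0.72 log units; beyond the scatter) and is the first change here beyond the scatter. In place of (2-oxo-1,3-oxazolidin-5-yl)methyl, the same group gives a 7.1-fold higher number from compound 1 to compound 3 (0.85 log units; beyond the scatter) on the same shared core. Nothing available accounts for this loss.

On these data alone, whether the ring itself or the placement of the hydroxyl goes with the loss remains open. Also open, as far as these compounds go, is how an amine or a carboxylic acid on the chain would read in this assay here.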